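The source may report more compounds than this note shows. Statements on the series, on what has been measured and on what is new or still open speak of the compounds shown alone.

Working notes on the series. Of the compounds shown here, two have been read so far in a physicochemical assay for lipophilicity, read by HPLC, measured as octanol-water partition; a lower number here means a more polar compound, a higher number a more lipophilic compound. Compound 1 `N#Cc1c(-c2ccccc2)[n+]([O-])c2ccc(/C=N/NC(=O)c3ccncc3)cc2[n+]1[O-]` gives 1 and compound 2 `Nc1cccc(C(=O)N/N=C/c2ccc3no[n+]([O-])c3c2)c1` gives 1.4 on the same scale. Compound 2 therefore holds the higher of the two numbers, and its gap to compound 1 lies beyond the scatter of repeat measurements. These two compounds differ in more than one place, so the gap cannot be assigned to any single group.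

Compound 3 `Nc1ccc(C(=O)N/N=C/c2ccc3no[n+]([O-])c3c2)cc1` is still unmeasured. The change from compound 2 is 4-aminophenyl in place of 3-aminophenyl on a carbonyl carbon and nothing else moves: the two have the same atoms, joined differently, with 4-aminophenyl in place of 3-aminophenyl on a carbonyl carbon. Within the data shown here, no measured pair shows what this swap does, so the expectation rests on the structural change alone, with compound 2 at 1.4 as its anchor. The expected no change at the digits printed from compound 2 to compound 3 (within the scatter) stays within the scatter, in neither direction. Compound 3 is estimated at 1.4 (expected range 1 to 1.8).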

Compound 3, partition coefficient: 1.2
Beside the measured number, compound 3's estimate is 0.20 log units above it; the measured number falls inside the stated range.
By their numbers in this assay, from the lowest: compounds 1, 3 and 2 (each within the scatter of the next, the first and the last beyond it).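

In this assay the series now holds its first pair that differs in one place, and swapping the group on a carbonyl carbon whose other neighbour is an amide-type nitrogen, 4-aminophenyl in place of 3-aminophenyl, gives a number 0.20 log units lower from compound 2 to compound 3 (within the scatter) for that pair. Neither the opening two compounds nor any earlier step could show this, since those two compounds differ in more than one place; the read-out now shows that, on this carbonyl carbon and with the shared core held fixed, the two aminophenyl isomers cannot be told apart beyond the scatter of repeat measurements. Nothing available on these compounds speaks to the reason for this result, so the pair stands as an observation only.

This single pair leaves open whether the same swap would also stay within the scatter on the core of compound 1, where a pyridine-bearing acyl group sits on the carbonyl carbon instead. It also leaves open what a different group would do at this place, such as a carboxylic acid or a methoxy group in place of the amine on the phenyl ring.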